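Fluoro on compound 3, held at the assay limit

The compounds below may be only part of what the source reports. "The series", "measured", "known", "first", "only" and "open" are said of these compounds alone.

Working notes on the shared core of compound 1 (`COCCOc1cc(/C=C/c2ccc3ccccc3c2)ccc1OC`), compound 2 (`Oc1ccc(/C=C/c2ccc3ccccc3c2)cc1`) and compound 3 (`COc1ccc(/C=C/c2ccc3ccccc3c2)cc1`). In a functional assay on P388 cells (Mus musculus) for inhibition (a lower number here means a stronger inhibitor, a higher number a weaker inhibitor), compound 1 gives 2990 nM as its half-maximal inhibitory concentration. Compound 2 gives 4060 nM on the same read-out. Compound 3 has only a limit of the assay (> 5000 nM), the sole such case of the three (the limit of > 5000 nM in this assay, at which 1 of the 3 values shown sits).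

The next change leads to compound 4 (`COc1ccc(/C=C/c2ccc3ccccc3c2)cc1F`): fluoro in place of hydrogen on an aromatic carbon (fluoro in place of hydrogen on an aromatic carbon, ortho to a methoxy group). Two measured steps end at compound 3, neither involving fluoro: an at least 1.6-fold higher number from compound 1 to compound 3 (0.22 log units; that floor lies within the scatter) and an at least 1.2-fold higher number from compound 2 to compound 3 (0.09 log units; that floor lies within the scatter). Both floors lie within the scatter, so they give no sign of a large step at this compound. No step beyond the scatter is therefore expected in this assay, and no direction is favoured. The expected step is a number no higher from compound 3 to compound 4 (the limit leaves the size open) in this estimate. For compound 4 the estimated value is 5000 nM, with an expected range of 2800 nM to 9000 nM as its span.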

Compound 4, half-maximal inhibitory concentration: 4490 nM
Compound 4: the middle estimate sits 1.1-fold (0.05 log units) above what was measured, and the stated range covers the measured number.
By their numbers in this assay, from the lowest: compounds 1, 2 and 4 (each within the scatter of the next). At a limit, above all of these: compound 3.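

In this assay, fluoro ortho to a methoxy group gives a reading inside the measurable range, but the step from the compound without it can be read only as a floor: an at least 1.1-fold lower number from compound 3 to compound 4 (0.04 log units; that floor lies within the scatter). The same place now has two substituents with measured numbers, and exchanging the 2-methoxyethoxy group for fluoro gives a 1.5-fold higher number from compound 1 to compound 4 (0.18 log units; within the scatter), so this single fluorine and that much longer chain are not separated in this assay. The true size of the fluoro step stays unfixed, and one value still bounds the comparison only as a limit: the limit of > 5000 nM in this assay, at which 1 of the 4 values shown sits.

From the compounds shown here alone, how an amine, a carboxylic acid or a longer alkoxy chain would read at this place remains open. Also open, going by these compounds, is whether fluoro would read the same with hydrogen in place of methyl on the oxygen, as in compound 2.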